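Aryl amide variation at the carbonyl carbon

The compounds below may be only part of what the source reports. "The series", "measured", "known", "first", "only" and "open" are said of these compounds alone.

The series shares one core and varies only the aryl group on the amide carbonyl carbon. Compound 1 `O=C(Nc1cccc(-c2oc3cc(-c4ccc(F)cc4)ccc3c(=O)c2O)c1)c1ccccc1F` gives 5630 nM in a functional assay on HeLa cells (Homo sapiens) for antiproliferative activity, read by CCK-8 assay, with a stated time of 72 h; on this read-out higher numbers stand for weaker inhibition and lower numbers for stronger inhibition. Compound 2 `COc1cccc(C(=O)Nc2cccc(-c3oc4cc(-c5ccc(F)cc5)ccc4c(=O)c3O)c2)c1` gives 5650 nM in this assay, with a 1.0-fold higher number from compound 1 to compound 2 (0.00 log units; within the scatter). Compound 3 `O=C(Nc1cccc(-c2oc3cc(-c4ccc(F)cc4)ccc3c(=O)c2O)c1)c1ccc(Cl)nc1` gives 4080 nM in this assay, the lowest of the three numbers, yet both a 1.4-fold lower number from compound 1 to compound 3 (0.14 log units; within the scatter) and a 1.4-fold lower number from compound 2 to compound 3 (0.14 log units; within the scatter) stay within the scatter, so none of the three compounds can be set apart from the others. Compound 4 `O=C(Nc1cccc(-c2oc3cc(-c4ccc(F)cc4)ccc3c(=O)c2O)c1)c1ccc(-c2ccccc2)cc1` is not yet measured; it differs from compound 3 by 4-phenylphenyl in place of 6-chloropyridin-3-yl on a carbonyl carbon. Among the measured compounds shown here, the steps that bear on this change are the three aryl exchanges already seen at the same carbonyl carbon, every one within the scatter; none of the groups tried so far carries two aromatic rings, so the present change goes beyond what has been measured. The expected step of a 1.1-fold higher number from compound 3 to compound 4 (0.04 log units; within the scatter) is therefore none beyond the scatter, with a wide range to cover the untested size of the group. Compound 4 is estimated at 4500 nM in this assay, with a range from 1500 nM to 14000 nM.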

Compound 4, half-maximal inhibitory concentration: > 100000 nM
Compound 4: no number, only a limit (the forecaster's own chance of this, stated with the estimate: 10%); middle value at least 22-fold (1.34 log units) away from the limit.
By their numbers in this assay, from the lowest: compounds 3, 1 and 2 (each within the scatter of the next). At a limit, above all of these: compound 4.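

Compound 4 gives no number in this assay, only a limit of the assay: the limit of > 100000 nM in this assay, at which 1 of the 4 values shown sits.

The position at the carbonyl carbon is therefore not indifferent to the aryl group: 2-fluorophenyl, 3-methoxyphenyl and 6-chloropyridin-3-yl stay within the scatter of one another, yet 4-phenylphenyl gives an at least 24-fold higher number from compound 3 to compound 4 (1.38 log units; beyond the scatter), an at least 17-fold higher number from compound 2 to compound 4 (1.24 log units; beyond the scatter) and an at least 17-fold higher number from compound 1 to compound 4 (1.24 log units; beyond the scatter). Among the compounds shown, the loss goes with the only group that has 2 six-membered aromatic rings, and this single example is too little to support a general pattern.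

The data do not tell whether the second ring itself or the overall size of the group accounts for the loss. Also open, going by these compounds, is whether a benzyl group, or a phenyl ring carrying an amine or a carboxylic acid, stays with compound 1, compound 2 and compound 3 or falls to the limit.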